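The source may report more compounds than this note shows. Statements on the series, on what has been measured and on what is new or still open speak of the compounds shown alone.

Measured so far:
Compound 1, `CC(C)(C)c1cc(C(C)(C)C)c2oc(C(c3ccccc3)c3c[nH]c4ccc([N+](=O)[O-])cc34)cc2c1`: 48200 nM
Compound 2, `CC(C)(C)c1cc(C(C)(C)C)c2oc(C(c3ccc(Cl)cc3)c3c[nH]c4ccc([N+](=O)[O-])cc34)cc2c1`: 36900 nM

For the measured compounds named here, in a functional assay on SiHa cells (Homo sapiens) for cytotoxicity (a lower number here means a stronger inhibitor, a higher number a weaker inhibitor), compound 2 gives the lowest of the two numbers, but the single measured step, a 1.3-fold lower number from compound 1 to compound 2 (0.12 log units; within the scatter), lies within the scatter, so the two compounds cannot be told apart. Compound 3, `COc1ccc(C(c2cc3cc(C(C)(C)C)cc(C(C)(C)C)c3o2)c2c[nH]c3ccc([N+](=O)[O-])cc23)cc1`, differs from compound 2 by methoxy in place of chloro on an aromatic carbon. Going by the values given here, only that one step bears on this change, and it was small, so no change beyond the scatter is expected here: compound 3 is expected to give 40000 nM, between 15000 nM and 110000 nM, which would be a step of a 1.1-fold higher number from compound 2 to compound 3 (0.04 log units; within the scatter).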

Compound 3, half-maximal inhibitory concentration: > 100000 nM
Compound 3: a limit, no number; the forecaster's own chance of this, stated with the estimate: 10%; at least 2.5-fold (0.39 log units) between middle value and limit.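

In this assay compound 3 reaches only a limit, > 100000 nM, and not a number. Replacing hydrogen with chloro had left the reading within the scatter, but methoxy on this aromatic carbon moves it beyond the scatter, with an at least 2.7-fold higher number from compound 2 to compound 3 (0.43 log units; beyond the scatter) and an at least 2.0-fold higher number from compound 1 to compound 3 (0.31 log units; beyond the scatter), so this position does not accept every group alike. The full size of both steps stays unknown, and the reading stops at a ceiling: the limit of > 100000 nM in this assay, at which 1 of the 3 values shown sits.

From the compounds shown here alone, whether an amine, a carboxylic acid or a longer chain such as ethoxy would track with chloro or with methoxy at this position stays open.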